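Pyridyl swap on the amide series: compound 3 estimate

The compounds below may be only part of what the source reports. "The series", "measured", "known", "first", "only" and "open" are said of these compounds alone.

Working notes on a pair of amides sharing one core. Compound 1 `C[C@H](NC(=O)c1cc(C2CC2)nn1C)c1nc(-c2ccccc2)no1` and compound 2 `Cc1ccnc(-c2noc([C@H](C)NC(=O)c3cc(C(F)(F)F)nn3C)n2)c1` were both tested in an assay on T-REx-293 cells for inhibition of potassium channel subfamily T member 1 (Homo sapiens), read by patch clamp; on this read-out lower numbers stand for stronger inhibition and higher numbers for weaker inhibition. Compound 1 gives 11400 nM, and compound 2 gives 4470 nM, which is the lowest of the two numbers; the gap to compound 1 lies beyond the scatter. The two compounds differ in more than one place, so their values are only stated side by side and no single change is credited.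

Compound 3 `C[C@H](NC(=O)c1cc(C(F)(F)F)nn1C)c1nc(-c2cccnc2)no1` has not been measured. It differs from compound 2 in one place: pyridin-3-yl in place of 4-methylpyridin-2-yl on an aromatic carbon. Going by the values given here, no measured pair shows this change, so its effect is unknown from the data. A modest step toward a weaker number is expected, close to the scatter, as a 1.6-fold higher number from compound 2 to compound 3 (0.19 log units; within the scatter). Compound 3 is expected to give 7000 nM in this assay, between 2500 nM and 20000 nM.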

Compound 3, half-maximal inhibitory concentration: 11800 nM
Beside the measured number, compound 3's estimate is 1.7-fold (0.23 log units) below it; measured number inside the range.
By their numbers in this assay, from the lowest: compound 2; then compounds 1 and 3 (each within the scatter of the next).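

In this assay, the aromatic carbon between two ring nitrogen atoms now has its first single-change reading: pyridin-3-yl in place of 4-methylpyridin-2-yl gives a 2.6-fold higher number from compound 2 to compound 3 (0.42 log units; beyond the scatter). This position is therefore sensitive to the choice of pyridine group, even though both groups are one six-membered aromatic ring with 1 hetero atom and the count of hydrogen-bond acceptors stays the same. The methyl group and the place of the ring nitrogen change together in this step, and no measurement in hand accounts for the shift.

Open, going by these compounds, is how an unsubstituted pyridin-2-yl would read here, a group that would separate those two changes. Also open, on these data alone, is whether an amine or a carboxylic acid on the pyridine would give a lower number than compound 2 with 4470 nM.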